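Swapping a Carbonyl Arm for a Sulfonyl Arm

The compounds below may be only part of what the source reports. "The series", "measured", "known", "first", "only" and "open" are said of these compounds alone.

Compound 1 `COC(=O)CC(=O)N1N=C(c2ccc(-n3cncn3)cc2)CC1c1ccc(N(C)C)cc1` gives 1.5% in a functional assay on NCI-H1975 cells (Homo sapiens) for inhibition, read by sulforhodamine B assay, tested at 10 uM; on this read-out lower numbers stand for less inhibition and higher numbers for more inhibition at the one concentration tested (going by the name of the read-out). Among the compounds with values here, compound 2 `CN(C)c1ccc(C2CC(c3ccc(-n4cncn4)cc3)=NN2C(=O)/C=C/c2ccccc2)cc1` gives -2.3%, the lowest of the two numbers; the only measured step, a number 3.8 percentage points lower from compound 1 to compound 2 (within the scatter), lies within the scatter. Compound 3 `CN(C)c1ccc(C2CC(c3ccc(-n4cncn4)cc3)=NN2S(=O)(=O)c2ccc(F)cc2)cc1` differs from compound 2 by (4-fluorophenyl)sulfonyl in place of (2-phenylethenyl)carbonyl on an amine nitrogen in a ring. That earlier step exchanged one group on a carbonyl for another, whereas here a sulfonyl group enters, so it bears only loosely on the change. Both measured compounds show little inhibition, so compound 3 is expected to stay close to them, with a step of a number 7.3 percentage points higher from compound 2 to compound 3 (within the scatter) of no clear direction. Compound 3 is estimated at 5%, between -15% and 25%.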

Compound 3, a percentage reported as inhibition, at one concentration (the size of the read-out at that concentration, not a potency): -0.5%
Estimate against measurement, compound 3: 5.5 percentage points above; measured number inside the range.
By their numbers in this assay, from the lowest: compounds 2, 3 and 1 (each within the scatter of the next).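

On the amine nitrogen in the ring, a sulfonyl arm now joins two carbonyl arms, and this assay does not separate them: the exchange gives a number 1.8 percentage points higher from compound 2 to compound 3 (within the scatter) and, against the other carbonyl arm, a number 2 percentage points lower from compound 1 to compound 3 (within the scatter) in the same read-out. This position has therefore taken three different groups, including an aromatic sulfonyl, without any step beyond the scatter. No measurement shown offers a reason for this.

Still open, from the compounds shown here alone, is whether an amine or a carboxylic acid on this nitrogen would give clear inhibition.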